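Trifluoromethyl addition on the sulfonamide anilinopyrimidine imine

A few compounds are considered here, and "the series" means these few. Any claim that something is new, unique, unknown or untested is made for them only; others in the source may bear on it.

Compound 3 `CC(C)Nc1nc(Nc2ccc(S(N)(=O)=O)cc2)ncc1/N=C/c1ccccc1` returns only a limit in a functional assay on HCT-116 cells (Homo sapiens) for antiproliferative activity, read by MTT assay (on this read-out higher numbers stand for weaker inhibition and lower numbers for stronger inhibition), namely > 100000 nM. Compound 1 `NS(=O)(=O)c1ccc(Nc2ncc(/N=C/c3ccc(C(F)(F)F)cc3)c(NC3CCCC3)n2)cc1` likewise returns only a limit, > 100000 nM. Compound 2 `CC(C)Nc1nc(Nc2ccc(N3CCN(C)CC3)cc2)ncc1/N=C/c1ccc(C(F)(F)F)cc1` gives a number, 42200 nM. Among these values compound 3 thus stands at the limit of > 100000 nM in this assay, at which 2 of the 3 values shown sit. Compound 4 `CC(C)Nc1nc(Nc2ccc(S(N)(=O)=O)cc2)ncc1/N=C/c1ccc(C(F)(F)F)cc1` differs from compound 3 by trifluoromethyl in place of hydrogen on an aromatic carbon. For the measured compounds named here, no measured pair isolates this change, so its step size is not known. Compound 1 already carries the trifluoromethyl together with the sulfonamide and reaches only its limit of > 100000 nM, so no shift beyond the scatter is expected in this assay. Compound 4 is therefore estimated at 150000 nM, with a range from 50000 nM to 500000 nM, most likely again reported as a limit. The expected step from compound 3 to compound 4 is a step that the limit leaves unreadable from compound 3 to compound 4.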

Compound 4, half-maximal inhibitory concentration: > 100000 nM
Compound 4: only a limit was reported; the forecaster's own chance of this, stated with the estimate: 75%; the middle value lies beyond the limit too.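

Sulfamoyl in place of 4-methylpiperazin-1-yl on an aromatic carbon gives an at least 2.3-fold higher number from compound 2 to compound 4 (0.37 log units; beyond the scatter), the first step in the series with a readable direction. The steps to compound 4 from compound 3 and from compound 1 cannot be read, with a limit at both ends. In this assay, the sulfamoyl compounds 1, 3 and 4 all give a limit and not a number: the limit of > 100000 nM in this assay, at which 3 of the 4 values shown sit.

As far as these compounds go, the size of the trifluoromethyl change and of isopropyl in place of cyclopentyl remains open. Also open, from the compounds shown here alone, is how a carboxylic acid or a morpholine in place of sulfamoyl would read.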